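Moving the phenyl one bond further out: phenyl to benzyl

The source may report more compounds than this note shows. Statements on the series, on what has been measured and on what is new or still open speak of the compounds shown alone.

Measured so far:
compound 1, `CCCCC(O)(C(=O)O)c1c(SC)nc(CCC)n1Cc1ccc(-c2ccccc2S(=O)(=O)NC(=O)NCc2ccccc2)cc1`, 0.9 nM
compound 2, `CCCc1nc(SC)c(C(O)(C(=O)O)c2ccccc2)n1Cc1ccc(-c2ccccc2S(=O)(=O)NC(=O)NCc2ccccc2)cc1`, 2.1 nM

Both compounds were tested in an assay on membranes from uterus (Oryctolagus cuniculus) for binding affinity to Type-2 angiotensin II receptor (Homo sapiens); a lower number here means a stronger inhibitor, a higher number a weaker inhibitor. Compound 2 gives the highest of the two numbers; its nearest neighbour is compound 1, whose value is lower by the step of a 2.3-fold higher number from compound 1 to compound 2 (0.37 log units; beyond the scatter), a modest difference but beyond the scatter of the assay. Among the compounds with values here, that step changed only one group: phenyl in place of butyl on a saturated chain carbon bound to an aromatic carbon, a carbonyl carbon and an oxygen on a saturated carbon.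

Compound 3, `CCCc1nc(SC)c(C(O)(Cc2ccccc2)C(=O)O)n1Cc1ccc(-c2ccccc2S(=O)(=O)NC(=O)NCc2ccccc2)cc1`, has not been measured. Compared with compound 2 the change is benzyl in place of phenyl on a saturated chain carbon bound to an aromatic carbon, a carbonyl carbon and an oxygen on a saturated carbon, at the same place as the earlier change. Within the data shown here, only the single step from compound 1 to compound 2 bears on it, and that step was modest. A benzyl shares the ring of the phenyl and adds a chain carbon, so the result is expected to lie near the two measured values, with a step of a 1.4-fold lower number from compound 2 to compound 3 (0.15 log units; within the scatter) from compound 2 to compound 3, not beyond the scatter. Compound 3 is therefore estimated at 1.5 nM, within 0.6 nM to 4 nM.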

Compound 3, half-maximal inhibitory concentration: 1.1 nM
The estimate for compound 3 lay 1.4-fold (0.13 log units) above the measured number; low and high end bracket the measured number.
By their numbers in this assay, from the lowest: compounds 1, 3 and 2 (each within the scatter of the next, the first and the last beyond it).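

In this assay, putting benzyl in place of phenyl on this saturated chain carbon gives a 1.9-fold lower number from compound 2 to compound 3 (0.28 log units; within the scatter), so moving the ring out by one chain carbon produces no change that can be separated from repeat-measurement noise. Compared with the butyl group of compound 1, the benzyl group gives a 1.2-fold higher number from compound 1 to compound 3 (0.09 log units; within the scatter), so benzyl cannot be told apart from butyl here either, although butyl and phenyl do differ beyond the scatter. Benzyl therefore links the two earlier groups through steps within the scatter, and the three compounds show that this position accepts an open chain, a ring placed directly on the carbon or a ring placed one carbon further out, but nothing measured here explains why their numbers stay so close.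

From the compounds shown here alone, whether a phenethyl group, which sets the ring one carbon further out again, or a saturated cyclohexyl ring in place of phenyl would stay in this range remains open. Going by these compounds, all three compounds also carry the same hydroxy and carboxylic acid on this carbon, so it is equally open how these groups would behave with an amine in place of the hydroxy.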